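Urea series: chloro step from compound 2 to compound 3

The source may hold more compounds than are shown below. What is called first, only, known or untested is meant among the compounds shown, and "the series" means these compounds.

Measured so far in a functional assay on HT-29 cells (Homo sapiens) for cytotoxicity, read by MTT assay, with a stated time of 72 h; on this read-out lower numbers stand for stronger inhibition and higher numbers for weaker inhibition:
compound 1 `CN(C)CCCNc1nc(-c2ccc(NC(=O)Nc3ccc(Cl)cc3)cc2)nc2c(Cl)c(Cl)sc12` gives 330 nM
compound 2 `CCN(CC)CCCNc1nc(-c2ccc(NC(=O)Nc3ccccc3)cc2)nc2c(Cl)c(Cl)sc12` gives 820 nM

Compound 2 stands at the higher of the two numbers in this assay, and the gap to compound 1 lies beyond the usual scatter. Compound 3 `CCN(CC)CCCNc1nc(-c2ccc(NC(=O)Nc3ccc(Cl)cc3)cc2)nc2c(Cl)c(Cl)sc12` is compound 2 with chloro in place of hydrogen on an aromatic carbon. For the measured compounds named here, no measured pair isolates this change; compound 1 carries the same chloro on a different amine end and gives 330 nM. For compound 3 the expected step is a 2.1-fold lower number from compound 2 to compound 3 (0.31 log units; beyond the scatter), downward and just beyond the scatter. Compound 3 is estimated at 400 nM, range 180 nM to 900 nM.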

Compound 3, half-maximal inhibitory concentration: 250 nM
Beside the measured number, compound 3's estimate is 1.6-fold (0.20 log units) above it, within the range that was stated.
By their numbers in this assay, from the lowest: compounds 3 and 1 (each within the scatter of the next); then compound 2.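

In this assay, chloro in place of hydrogen on this aromatic carbon now has a pair of its own, and phenyl to 4-chlorophenyl gives a 3.3-fold lower number from compound 2 to compound 3 (0.52 log units; beyond the scatter), a modest step beyond the scatter. With the chloro kept, diethylamino in place of dimethylamino gives a 1.3-fold lower number from compound 1 to compound 3 (0.12 log units; within the scatter), within the scatter, so this pair separates the two amine ends by nothing readable. Nothing available explains the size of the chloro step.

Open, going by these compounds, is whether fluoro, bromo or methoxy at this carbon gives a similar step. Also open, on these data alone, is whether a pyrrolidine or a longer chain at the amine end stays within the scatter.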